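Trading One Fluorinated Group for Another on an Aromatic Ring

The source may hold more compounds than are shown below. What is called first, only, known or untested is meant among the compounds shown, and "the series" means these compounds.

Four compounds share a core in which a short hydroxylated chain carries an amide on one side and a link to a second aromatic ring on the other. Compound 1 `CC(O)(CSc1ccc(S(F)(F)(F)(F)F)cc1)C(=O)Nc1ccc(S(F)(F)(F)(F)F)cc1` and compound 2 `CC(O)(CSc1ccc(OC(F)(F)F)cc1)C(=O)Nc1ccc(S(F)(F)(F)(F)F)cc1` join that second ring through sulfur; compound 3 `CC(O)(COc1ccc(S(F)(F)(F)(F)F)cc1)C(=O)Nc1ccc(S(F)(F)(F)(F)F)cc1` and compound 4 `CC(O)(COc1ccc(OC(F)(F)F)cc1)C(=O)Nc1ccc(S(F)(F)(F)(F)F)cc1` join it through oxygen. The difference between the two cores is not broken down here.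

In a functional assay on DU-145 cells (Homo sapiens) for antiproliferative activity, read by propidium iodide staining, with a stated time of 96 h (on this read-out higher numbers stand for weaker inhibition and lower numbers for stronger inhibition), compound 1 gives 22300 nM. Compound 2 gives 12500 nM in this assay, so that the change a group of 5 heavy atoms (1 carbon, 1 oxygen, 3 fluorine; no ring) in place of a group of 6 heavy atoms (5 fluorine, 1 sulfur; no ring), on an aromatic carbon made a step of a 1.8-fold lower number from compound 1 to compound 2 (0.25 log units; within the scatter). Compound 3 gives 24900 nM in this assay, a number that sits close to that of compound 1.

Compound 4 carries the same change as compound 2, namely (a group of 5 heavy atoms (1 carbon, 1 oxygen, 3 fluorine; no ring) in place of a group of 6 heavy atoms (5 fluorine, 1 sulfur; no ring), on an aromatic carbon), now set on the core of compound 3. Within the data shown here, since the single measured example of this change, from compound 1 to compound 2, stayed within the scatter, the step from compound 3 to compound 4 is expected to be of similar size, about a 1.8-fold lower number from compound 3 to compound 4 (0.25 log units; within the scatter), because compound 3 starts from 24900 nM. On that basis compound 4 is estimated at 14000 nM in this assay, with a likely span from 7000 nM to 30000 nM.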

Compound 4, half-maximal inhibitory concentration: 24800 nM
Estimate against measurement, compound 4: 1.8-fold (0.25 log units) below; measured number inside the range.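

On the core of compound 3, putting trifluoromethoxy in place of the group of 6 heavy atoms gives, in this assay, a 1.0-fold lower number from compound 3 to compound 4 (0.00 log units; within the scatter). Set side by side, the two examples of this change do not differ by more than repeated measurements of this kind usually would: the same change on two cores in this assay, a 1.8-fold lower number (0.25 log units; within the scatter) from compound 1 to compound 2 and a 1.0-fold lower number (0.00 log units; within the scatter) from compound 3 to compound 4, 1.8-fold (0.25 log units) apart, within the scatter of two such steps So nothing here suggests that the sulfur-linked and oxygen-linked cores respond differently to the swap, but this does not prove that its effect carries over, since neither step can be told apart from the scatter and two pairs of compounds form a very small sample.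

The compounds shown leave open what a different group on that same aromatic carbon, such as a nitrile, an amine or a carboxylic acid, would do to the number, and whether any such group could produce a step large enough to test transfer between the two cores properly. They also leave open whether the same swap would behave alike on the ring attached to the amide, where all four compounds keep the group of 6 heavy atoms.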